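Swapping a Benzyl for a Hexyl on the Triazole

The source may report more compounds than this note shows. Statements on the series, on what has been measured and on what is new or still open speak of the compounds shown alone.

Going by the values given here, compound 1, `Nc1nc(-c2ccc(Cl)cc2)cc(-c2ccc(OCc3cn(Cc4ccccc4)nn3)cc2O)n1`, is the one compound of this set with a number in an ADME assay on cells (Macrophage) for cytotoxicity, read by resazurin assay, with a stated time of 48 h (on this read-out higher numbers stand for lower toxicity in this test and lower numbers for higher toxicity in this test), where compound 1 gives 66600 nM, and so it stands alone as the reference point. Compound 2, `O=C(/C=C/c1ccc(Cl)cc1)c1ccc(OCc2cn(Cc3ccccc3)nn2)cc1O`, was also part of the study, but in this assay compound 2 gives "not determined" (no result reported), so no number is available for it. Compound 3, `CCCCCCn1cc(COc2ccc(-c3cc(-c4ccc(Cl)cc4)nc(N)n3)c(O)c2)nn1`, has not yet been measured. Its structure differs from compound 1 in one place: pentyl in place of phenyl on a saturated chain carbon bound to an aromatic nitrogen. Among the compounds with values here, no measured pair in the set shows what such a change does in this assay, so the account can only expect, for the step from compound 1 to compound 3, a move of a 1.1-fold lower number from compound 1 to compound 3 (0.05 log units; within the scatter), that is, nothing beyond the usual scatter in either direction. On that basis compound 3 is estimated at 60000 nM, with a likely range from 25000 nM to 150000 nM.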

Compound 3, half-maximal cytotoxic concentration: 30300 nM
Compound 3: middle estimate off by 2.0-fold (0.30 log units), on the high side; the measured number falls inside the stated range.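

In this assay, the change from benzyl to hexyl at this position brings a 2.2-fold lower number from compound 1 to compound 3 (0.34 log units; beyond the scatter), a modest step towards higher toxicity in this test, and so the first sign that this read-out responds to what sits on a saturated chain carbon bound to an aromatic nitrogen. This single pair replaces a ring-bearing group with an open chain in one move, so it cannot separate the loss of the phenyl ring from the effect of the chain that enters. No measurement at hand bears on why the number moved.

Going by these compounds alone, compound 2 has no number, so no step involving it can be read. From the compounds shown here alone, whether a longer chain such as octyl, a shorter one such as propyl, or a chain ending in an amine would move the number further remains open.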